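This account rests on a few compounds, and the source may have more. Where it says the series, first, only, none or still open, it means among the compounds named here.

Working notes on the series. In a functional assay on SW1573 cells (Homo sapiens) for antiproliferative activity, with a stated time of 48 h (a lower number here means a stronger inhibitor of growth, a higher number a weaker inhibitor of growth), compound 1 `C/C=C/[C@H]1C/C=C\C[C@@H](Cl)[C@@H](C[C@@H](O)C=C=CBr)O1` gives > 10 ug/mL, which is a limit and not a number. In this assay compound 2 `C/C=C/[C@H]1C/C=C\C[C@@H](Cl)[C@@H](C[C@H](C=C=CBr)OC(C)=O)O1` gives > 10 ug/mL, also a limit. Compound 2 therefore has no numerical position in the series, and the only reference point is the limit of > 10 ug/mL in this assay, at which 2 of the 2 values shown sit.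

Compound 3 `C/C=C/[C@H]1C/C=C\C[C@@H](Cl)[C@@H](C[C@@H](C=C=CBr)OC(C)=O)O1` is the next to be considered, and the change from compound 2 is the two compounds have the same atoms and bonds; at least one stereo element is drawn with a configuration in one of them and without one in the other: 1 of 8 stereo elements differ; a stereocentre at a saturated chain carbon is drawn R in compound 2 and S in compound 3. A stereocentre at a saturated chain carbon is drawn R in compound 2 and S in compound 3.

Within the data shown here, the one measured step nearby is a step that the two limits leave unreadable from compound 1 to compound 2. It is a different kind of change, acetyl in place of hydrogen on an oxygen on a saturated carbon, and its size cannot be read, so it gives no measure for an inversion. With compound 2 at > 10 ug/mL, no step beyond the scatter can be predicted in this assay, and no direction is favoured. The estimated step that the limit leaves unreadable from compound 2 to compound 3 is expected to be of no readable size. Most likely the result will again be only a limit.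

The expected value for compound 3 is 14 ug/mL, with an estimated range of 6 ug/mL to 30 ug/mL.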

Compound 3, concentration for 50% growth inhibition: > 10 ug/mL
Compound 3: only a limit was reported; the forecaster's own chance of this, stated with the estimate: 75%; the middle value does not contradict the limit.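

In this assay compound 3 gives > 10 ug/mL, a limit and not a number, so no step from compound 2 to compound 3 can be read: the limit of > 10 ug/mL in this assay, at which 3 of the 3 values shown sit.

The compounds shown leave open whether the configuration at that saturated chain carbon has any effect on growth inhibition in this assay.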